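The source may hold more compounds than are shown below. What is called first, only, known or untested is meant among the compounds shown, and "the series" means these compounds.

Measured compounds:

Compound 1, `COc1ccc(S(=O)(=O)N2CCc3cccc(-c4ccc(C#N)cc4)c32)cc1`, gives 29.5 nM in a functional assay on NCI-H460 cells (Homo sapiens) for inhibition, with a stated time of 72 h; a lower number here means a stronger inhibitor, a higher number a weaker inhibitor.
Compound 2, `COc1ccc(S(=O)(=O)N2CCc3cccc(-c4ccc(O)cc4)c32)cc1`, gives 114 nM in this assay.
Compound 3, `COc1ccc(-c2cccc3c2N(S(=O)(=O)c2ccc(OC)cc2)CC3)cc1`, gives 302 nM in this assay.

Compound 3 holds the highest number of the three, the nearest being compound 2, with the gap a 2.6-fold higher number from compound 2 to compound 3 (0.42 log units; beyond the scatter), and the furthest compound 1, with the gap a 10-fold higher number from compound 1 to compound 3 (1.01 log units; beyond the scatter). Compound 4, `COc1ccc(S(=O)(=O)N2CCc3cccc(-c4ccccc4)c32)cc1`, has not yet been measured. It differs from compound 3 by hydrogen in place of methoxy on an aromatic carbon.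

Among the compounds with values here, no measured step removes the methoxy outright, so the bearing steps are indirect. The step from compound 2 to compound 3 shows that adding a methyl on the oxygen raised the number by a modest amount, and the step from compound 1 to compound 3 shows that the cyano analogue sits far lower. Both suggest the methoxy of compound 3 is not the most favourable group at this place, so removing it is expected to lower the number modestly, or leave it within the scatter. Compound 4 is therefore expected to show a 1.5-fold lower number from compound 3 to compound 4 (0.18 log units; within the scatter), giving an estimated 200 nM, with a range from 60 nM to 600 nM.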

Compound 4, half-maximal inhibitory concentration: 213 nM
For compound 4 the middle estimate is 1.1-fold (0.03 log units) below the measured one; the range from low to high includes it.
By their numbers in this assay, from the lowest: compound 1; then compounds 2, 4 and 3 (each within the scatter of the next, the first and the last beyond it).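

With the methoxy gone, the unsubstituted phenyl of compound 4 gives a 1.4-fold lower number from compound 3 to compound 4 (0.15 log units; within the scatter) and, against the hydroxy analogue, a 1.9-fold higher number from compound 2 to compound 4 (0.27 log units; within the scatter), so hydrogen at this place, para to a large group, cannot be told apart in this assay from either oxygen group, even though those two differ from each other (a 2.6-fold higher number from compound 2 to compound 3 (0.42 log units; beyond the scatter)). The cyano group is the only one of the four that stands clearly apart from hydrogen here, with a 7.2-fold higher number from compound 1 to compound 4 (0.86 log units; beyond the scatter), which makes the low number of compound 1 a feature of that group rather than a general result of substitution at this place. Nothing at hand bears on why these groups differ.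

As far as these compounds go, whether an amine, a carboxylic acid or a trifluoromethyl group here would track the cyano group or hydrogen remains open. So does whether the cyano group would hold its standing elsewhere on this ring.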